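A few compounds are considered here, and "the series" means these few. Any claim that something is new, unique, unknown or untested is made for them only; others in the source may bear on it.

The measured compounds and their values in a functional assay on MOLT-4 cells (Homo sapiens) for inhibition, read by sulforhodamine B assay, with a stated time of 48 h; on this read-out lower numbers stand for stronger inhibition of growth and higher numbers for weaker inhibition of growth:

Compound 1, `COc1cc(-c2cc(/C=C/C(=O)c3ccc(Cl)c(Cl)c3)[nH]n2)cc(OC)c1OC`, gives 40600 nM.
Compound 2, `COc1ccc(-c2cc(/C=C/C(=O)c3ccc(N)cc3)[nH]n2)cc1OC`, gives 16500 nM.
Compound 3, `COc1ccc(-c2cc(/C=C/C(=O)c3cc(OC)c(OC)c(OC)c3)[nH]n2)cc1OC`, gives 8860 nM.

These three compounds share a common core and differ in the aryl group attached to the carbonyl carbon and in the pattern of substituents on the other aryl ring. Compound 1 stands at the top of the numbers, which on this read-out means the weakest inhibition of growth: compound 2 lies below it by a gap beyond the usual scatter, and compound 3 lies further still, so compound 1 is the least active of the three. Within the data shown here, no pair of measured compounds differs in only one place, so no single structural change can be read off directly from the measured values.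

Compound 4, `COc1cc(-c2cc(/C=C/C(=O)c3ccc(F)c(F)c3)[nH]n2)cc(OC)c1OC`, differs from compound 1 in one place: 3,4-difluorophenyl in place of 3,4-dichlorophenyl on a carbonyl carbon. Among the measured compounds shown here, both the leaving and the entering groups carry two halogens on the same ring positions, and nothing among the measured compounds shows what swapping one halogen pair for the other does. The step of a 1.1-fold higher number from compound 1 to compound 4 (0.04 log units; within the scatter) is expected to stay within the scatter, with no clear direction. Compound 4 is estimated to give about 45000 nM, within a range from 15000 nM to 130000 nM.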

Compound 4, concentration for total growth inhibition: 9090 nM
Compound 4: middle estimate off by 5.0-fold (0.69 log units), on the high side; the whole stated range lies above it.
By their numbers in this assay, from the lowest: compounds 3, 4 and 2 (each within the scatter of the next); then compound 1.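

In this assay, the choice of halogen pair on the ring attached to the carbonyl carbon clearly matters: 3,4-difluorophenyl in place of 3,4-dichlorophenyl gives a 4.5-fold lower number from compound 1 to compound 4 (0.65 log units; beyond the scatter). The two groups have the same ring and the same heavy-atom count, and their halogens occupy the same ring positions, so the identity of the halogens alone separates compound 1 from compound 4. Among these compounds, this is the first direct reading of a single structural change, and it shows that this position responds to a swap between two closely matched groups, although nothing available here explains the difference.

The compounds shown leave open how other groups at this position would compare, such as a plain phenyl group, a 3,4-dibromophenyl group or a ring carrying a single fluorine atom. Among the compounds shown here, they also leave open whether the same swap would produce a similar change with a different substituent pattern on the other aryl ring, such as the one in compound 2 or compound 3.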